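The source may report more compounds than this note shows. Statements on the series, on what has been measured and on what is new or still open speak of the compounds shown alone.

Compound 3 `O=C(NS(=O)(=O)C1CC1)c1ccc(Nc2nc(NC3(c4ccc(Cl)cc4)CC3)nc(OCC(F)(F)F)n2)cc1` stands highest of the three numbers recorded so far in an ADME assay on microsomes from liver (Homo sapiens) for metabolic stability, with a stated time of 10 min (on this read-out higher numbers stand for a more stable compound and lower numbers for a less stable compound), where compound 3 gives 100%. Compound 1 `CC(C)(C)NC(=O)NCCS(=O)(=O)NC(=O)c1ccc(Nc2nc(NC3(c4ccc(Cl)cc4)CC3)nc(OCC(F)(F)F)n2)cc1` gives 96% in this assay, and compound 2 `CC(C)(C)OC(=O)NCCS(=O)(=O)NC(=O)c1ccc(Nc2nc(NC3(c4ccc(Cl)cc4)CC3)nc(OCC(F)(F)F)n2)cc1` gives 92%; between those two the change at the carbonyl carbon amounts to a number 4 percentage points lower from compound 1 to compound 2 (within the scatter). Compound 4 `CN(C)S(=O)(=O)NC(=O)c1ccc(Nc2nc(NC3(c4ccc(Cl)cc4)CC3)nc(OCC(F)(F)F)n2)cc1` differs from compound 3 by dimethylamino in place of cyclopropyl on a sulfonyl sulfur. The measured steps that bear on this change are the two that also alter the group on the sulfonyl sulfur: a number 4 percentage points higher from compound 1 to compound 3 (within the scatter) and a number 8 percentage points higher from compound 2 to compound 3 (within the scatter). Among the measured compounds shown here, neither exchange of the sulfonyl substituent moved this assay beyond its scatter, even where the group leaving was far larger than the one entering, and no other measured pair speaks to the exchange. On that basis no step beyond the scatter is expected from compound 3 to compound 4. Compound 4 is therefore expected to show a number 5 percentage points lower from compound 3 to compound 4 (within the scatter), with an estimated value of 95%, ranging from 82% to 100%.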

Compound 4, percent of the compound remaining: 86%
Beside the measured number, compound 4's estimate is 9 percentage points above it, and the stated range covers the measured number.
By their numbers in this assay, from the lowest: compounds 4, 2, 1 and 3 (each within the scatter of the next, the first and the last beyond it).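

On the sulfonyl sulfur, dimethylamino in place of cyclopropyl gives the only step shown beyond the scatter in this assay (a number 14 percentage points lower from compound 3 to compound 4 (beyond the scatter)), even though both groups count the same heavy atoms, so this position is not indifferent to the group it carries. Against the longer chains on the sulfur, dimethylamino stays within the scatter (a number 6 percentage points lower from compound 2 to compound 4 (within the scatter); a number 10 percentage points lower from compound 1 to compound 4 (within the scatter)), so the step is seen only against cyclopropyl and is modest. Nothing measured here accounts for the step.

The compounds shown leave open whether the step follows from the nitrogen attached to the sulfur or from the loss of the ring. An isopropyl group or an azetidine ring on the same sulfur would separate these two readings.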